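Cytotoxicity notes on the shared core: iodo for benzyloxy

A few compounds are considered here, and "the series" means these few. Any claim that something is new, unique, unknown or untested is made for them only; others in the source may bear on it.

In an ADME assay on L929 cells (Mus musculus) for cytotoxicity, read by resazurin assay, with a stated time of 72 h (a higher number here means a weaker inhibitor, a lower number a stronger inhibitor), compound 1 `O=C(/C=C/c1ccc2c(c1)B(O)OC2)c1ccc(OCc2ccccc2)cc1` gives > 10 ug/mL, which is a limit of the assay rather than a number. Compound 2 `COc1cccc(C(=O)CCc2ccc3c(c2)B(O)OC3)c1` likewise returns only the limit > 10 ug/mL. Compound 3 `O=C(/C=C/c1ccc2c(c1)B(O)OC2)c1ccc(Cl)c(Cl)c1` also sits at the limit with > 10 ug/mL. All three values coincide at the limit of > 10 ug/mL in this assay, at which 3 of the 3 values shown sit, so compound 1 stands level with the others and nothing separates them in this assay. Compound 4 `O=C(/C=C/c1ccc2c(c1)B(O)OC2)c1ccc(I)cc1` differs from compound 1 by iodo in place of benzyloxy on an aromatic carbon. Among the compounds with values here, no measured pair isolates this change, so no step beyond the scatter is expected in either direction. Compound 4 is expected at 10 ug/mL, within a range of 5 ug/mL to 30 ug/mL. The step this implies, a number no higher from compound 1 to compound 4 (the limit leaves the size open), is expected to stay within the scatter.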

Compound 4, half-maximal inhibitory concentration: > 10 ug/mL
Compound 4 was reported as a limit (the forecaster's own chance of this, stated with the estimate: 75%); the middle value sits exactly at the limit.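

Compound 1 and compound 4 both give only a limit in this assay, so no step can be read between them: the limit of > 10 ug/mL in this assay, at which 4 of the 4 values shown sit.

The compounds shown leave open whether iodo in place of benzyloxy changes the half-maximal inhibitory concentration at all.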